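Ring nitrogen aryl swap: from compound 3 to compound 4

The compounds below may be only part of what the source reports. "The series", "measured", "known", "first", "only" and "open" are said of these compounds alone.

Compound 3 `Nc1scc(CN2CCN(c3ccc(Cl)c(C(F)(F)F)c3)CC2)c1C(=O)c1ccc(Cl)cc1` gives 3% in an assay on CHO cells for displacement of a labelled ligand from adenosine receptor A3 (Homo sapiens), read by scintillation counting, with a stated time of 120 min, tested at 10 uM (a lower number here means less inhibition, a higher number more inhibition at the concentration tested (going by the name of the read-out)), and is the highest of the three numbers measured, but only by a margin inside the scatter. Compound 1 `COc1ccc(N2CCN(Cc3csc(N)c3C(=O)c3ccc(Cl)cc3)CC2)cc1` gives 0% and compound 2 `Nc1scc(CN2CCN(c3cccc(C(F)(F)F)c3)CC2)c1C(=O)c1ccc(Cl)cc1` gives 0% in this assay, so all three numbers sit close together at the low end of the read-out. The steps between them are no change at the digits printed from compound 1 to compound 2 (within the scatter), a number 3 percentage points higher from compound 1 to compound 3 (within the scatter) and a number 3 percentage points higher from compound 2 to compound 3 (within the scatter); none reaches beyond the scatter, whether the whole aryl group on the ring nitrogen is exchanged or only a chloro is added to it.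

Compound 4 `Nc1scc(CN2CCN(c3ccncc3)CC2)c1C(=O)c1ccc(Cl)cc1` differs from compound 3 as follows: pyridin-4-yl in place of 4-chloro-3-(trifluoromethyl)phenyl on an amine nitrogen in a ring. Within the data shown here, the steps that bear on this change are the two exchanges of the aryl group on the ring nitrogen, no change at the digits printed from compound 1 to compound 2 (within the scatter) and a number 3 percentage points higher from compound 1 to compound 3 (within the scatter), both flat within the scatter. Nothing in the series shows that this position moves the read-out in this assay at all, so no step beyond the scatter is expected from compound 3 to compound 4: the expected step is a number 1 percentage points lower from compound 3 to compound 4 (within the scatter). For compound 4 the estimate in this assay is 2%, with a range from -8% to 12%.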

Compound 4, a percentage reported as inhibition, at one concentration (the size of the read-out at that concentration, not a potency): 2%
Compound 4: middle estimate and measured number agree at the digits printed, and the stated range covers the measured number.
By their numbers in this assay, from the lowest: compounds 1, 2, 4 and 3 (each within the scatter of the next).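

The exchange on the amine nitrogen in a ring now extends from aromatic rings of carbon only to a ring with 1 hetero atom. In this assay the new group gives a number 1 percentage points lower from compound 3 to compound 4 (within the scatter), while the comparisons with the other two aryl groups give a number 2 percentage points higher from compound 2 to compound 4 (within the scatter) and a number 2 percentage points higher from compound 1 to compound 4 (within the scatter). Across these four compounds, the read-out therefore shows no step beyond the scatter, even when 11 heavy atoms leave, 6 enter and 1 hydrogen-bond acceptor is added; no evidence is available that would explain this flat result.

All four numbers lie so close together at the low end of the read-out that these compounds do not show whether the group at this position can influence this assay at all. As far as these compounds go, it remains open whether a benzyl group, a longer alkyl chain or a carboxylic acid on this ring nitrogen would give a number beyond the scatter, and whether a change to the shared core would do so.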